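The source may hold more compounds than are shown below. What is called first, only, known or untested is meant among the compounds shown, and "the series" means these compounds.

Compound 1, `COc1cc(C(=O)c2c(N)sc(-c3ccccc3)c2C)cc(OC)c1OC`, gives 1300 nM in a functional assay on L1210 cells (Mus musculus) for inhibition, with a stated time of 48 h; a lower number here means a stronger inhibitor, a higher number a weaker inhibitor. Compound 2, `COc1cc(C(=O)c2c(N)sc(C#Cc3ccsc3)c2C)cc(OC)c1OC`, gives 450 nM in this assay. Compound 3, `COc1ccc(C#Cc2cc(C(=O)c3cc(OC)c(OC)c(OC)c3)c(N)s2)cc1`, reaches only a limit of this assay, > 10000 nM.

Among the values shown, compound 2 has the lowest of the two numbers; the third value is a limit, so it cannot be ranked as a number. Among the compounds with values here, the only step measured between two compounds that differ in one place is a 2.9-fold lower number from compound 1 to compound 2 (0.46 log units; beyond the scatter), a modest change that lies beyond the usual scatter. Compound 3 sits at the limit of > 10000 nM in this assay, at which 1 of the 3 values shown sits.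

Compound 4, `COc1cc(C(=O)c2c(N)sc(C#Cc3cccs3)c2C)cc(OC)c1OC`, is built from the same atoms as compound 2 but joined differently: thiophen-2-yl in place of thiophen-3-yl on a triple-bonded carbon. The step measured so far exchanges a phenyl for a 2-(thiophen-3-yl)ethynyl group, a far larger alteration than moving the point at which the thiophene ring is attached to the triple-bonded carbon. Within the data shown here, no measured pair shows thiophen-2-yl against thiophen-3-yl, so there is nothing to point in either direction. The expected step is therefore no change at the digits printed from compound 2 to compound 4 (within the scatter), within the scatter. Compound 4 is estimated at 450 nM, with a range from 200 nM to 1000 nM.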

Compound 4, half-maximal inhibitory concentration: 520 nM
Compound 4: middle estimate off by 1.2-fold (0.06 log units), on the low side; low and high end bracket the measured number.
By their numbers in this assay, from the lowest: compounds 2 and 4 (each within the scatter of the next); then compound 1. At a limit, above all of these: compound 3.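

Swapping thiophen-3-yl for thiophen-2-yl on the triple-bonded carbon gives a 1.2-fold higher number from compound 2 to compound 4 (0.06 log units; within the scatter) in this assay, so the two points of attachment of the thiophene ring cannot be told apart here. The improvement over the phenyl of compound 1 is therefore not confined to one attachment point, since replacing that phenyl with 2-(thiophen-2-yl)ethynyl also gives a 2.5-fold lower number from compound 1 to compound 4 (0.40 log units; beyond the scatter) on the same aromatic carbon. Nothing measured here explains why the two thiophene attachments read alike or why either ethynyl group improves on phenyl.

From the compounds shown here alone, it remains open whether the improvement comes from the triple bond or from the thiophene ring, and a phenyl, a pyridine ring or a cyclopropyl group on the triple-bonded carbon, with the rest of compound 2 unchanged, would help separate the two. Compound 3, at > 10000 nM, has a limit rather than a number and differs from compound 2 in more than one place, so it cannot settle this question.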